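The source may report more compounds than this note shows. Statements on the series, on what has been measured and on what is new or still open speak of the compounds shown alone.

The three measured compounds, all tested in a functional assay on MCF7 cells (Homo sapiens) for antiproliferative activity, read by sulforhodamine B assay, with a stated time of 72 h, tested at 10 uM; on this read-out higher numbers stand for a weaker effect at the one concentration tested and lower numbers for a stronger effect:

Compound 1 `COc1cccc(C(=O)/C=C/c2cc(Br)cc(OC)c2O)c1` gives 77.3%.
Compound 2 `COc1cc(Cl)cc(/C=C/C(=O)c2ccc(Br)cc2)c1O` gives 38.2%.
Compound 3 `Cc1ccc(C(=O)/C=C/c2cc(F)cc(F)c2O)cc1` gives 33.9%.

Compound 2 stands second highest of the three numbers in this assay. Its nearest neighbour is compound 3, whose number is slightly lower, a gap that lies within the usual scatter, so no order between these two can be claimed. The furthest is compound 1, whose number is far higher, a gap beyond the scatter.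

Compound 4 `COc1cc(Br)cc(/C=C/C(=O)c2ccc(Br)cc2)c1O` has not yet been measured. It differs from compound 2 in one place: bromo in place of chloro on an aromatic carbon. Among the compounds with values here, no pair of measured compounds shows this exchange, so there is no measured step to rest on. The expectation in this assay is therefore of no step beyond the scatter, in either direction. Compound 4 is estimated at 36%, with a range from 18% to 58%. That estimate means a step of a number 2.2 percentage points lower from compound 2 to compound 4 (within the scatter), expected to stay within the scatter.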

Compound 4, a percentage reported as activity, at one concentration (the size of the read-out at that concentration, not a potency): 64.6%
Beside the measured number, compound 4's estimate is 28.6 percentage points below it; the whole stated range lies below it.
By their numbers in this assay, from the lowest: compounds 3 and 2 (each within the scatter of the next); then compound 4; then compound 1.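

In this assay the position para to a hydroxy group and meta to a methoxy group proves sensitive to which halogen it carries: bromo in place of chloro gives a number 26.4 percentage points higher from compound 2 to compound 4 (beyond the scatter) and so a weaker effect at the one concentration tested. The earlier compounds shown here offered no pair that tested this position, and this pair now shows that one heavy atom exchanged for another can matter, even though neither group adds a ring, a hydrogen-bond donor, a hydrogen-bond acceptor or a charge. Nothing available here explains why the exchange has this effect.

As far as these compounds go, whether a nitrile or an amine at this position would keep the effect of chloro or lose it as bromo does stays open. From the compounds shown here alone, it is also open whether the same exchange would give a similar step on a differently substituted core.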